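The source may report more compounds than this note shows. Statements on the series, on what has been measured and on what is new or still open speak of the compounds shown alone.

Measured compounds in a functional assay on HepG2 cells (Homo sapiens) for inhibition, read by MTT assay, with a stated time of 72 h; a higher number here means a weaker inhibitor, a lower number a stronger inhibitor:

- compound 1 `Cc1ccccc1-n1cc(COc2cccc(NC(=O)Nc3ccc(Cl)c(C(F)(F)F)c3)c2)nn1`: 3440 nM
- compound 2 `Cc1ccc(-n2cc(COc3cccc(NC(=O)Nc4ccc(Cl)c(C(F)(F)F)c4)c3)nn2)cc1`: 5430 nM
- compound 3 `CCc1ccccc1-n1cc(COc2cccc(NC(=O)Nc3ccc(Cl)c(C(F)(F)F)c3)c2)nn1`: 3530 nM

Compound 3 gives the second highest of the three numbers in this assay. Its nearest neighbour is compound 1, the step being a 1.0-fold higher number from compound 1 to compound 3 (0.01 log units; within the scatter), and its furthest is compound 2, with a 1.5-fold lower number from compound 2 to compound 3 (0.19 log units; within the scatter); both lie within the scatter.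

Compound 4 `CC(C)c1ccccc1-n1cc(COc2cccc(NC(=O)Nc3ccc(Cl)c(C(F)(F)F)c3)c2)nn1` is the next member of the series. The change from compound 3 is methyl in place of hydrogen on a saturated chain carbon bound to an aromatic carbon and a saturated chain carbon. Among the measured compounds shown here, the one measured step that bears on it is the earlier lengthening of the same chain, a 1.0-fold higher number from compound 1 to compound 3 (0.01 log units; within the scatter), which was within the scatter. On that basis compound 4 is expected to show no step beyond the scatter, a 1.0-fold higher number from compound 3 to compound 4 (0.02 log units; within the scatter), with an estimated value of 3700 nM and a range from 1800 nM to 7600 nM.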

Compound 4, half-maximal inhibitory concentration: 1900 nM
The estimate for compound 4 lay 1.9-fold (0.29 log units) above the measured number; the measured number falls inside the stated range.
By their numbers in this assay, from the lowest: compounds 4, 1, 3 and 2 (each within the scatter of the next, the first and the last beyond it).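

Adding the methyl that turns ethyl into isopropyl gives a 1.9-fold lower number from compound 3 to compound 4 (0.27 log units; within the scatter) in this assay, and the full change from methyl to isopropyl gives a 1.8-fold lower number from compound 1 to compound 4 (0.26 log units; within the scatter), so these three groups are not told apart at this place. Among the compounds shown here, only the comparison with the 4-methylphenyl of compound 2 gives a step beyond the scatter, a 2.9-fold lower number from compound 2 to compound 4 (0.46 log units; beyond the scatter), and it is the only such step among the four compounds. No measurement offered here accounts for this result.
As far as these compounds go, whether a tert-butyl group or a methoxy group in place of the isopropyl would move the number beyond the scatter from compound 1 remains open.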